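Swapping a Pyrimidine for a Chlorophenyl on a Piperazine

The source may hold more compounds than are shown below. What is called first, only, known or untested is meant among the compounds shown, and "the series" means these compounds.

Of the compounds shown here, three built on a shared core have been measured in a functional assay (brain) for inhibition, with Rattus norvegicus as the target; on this read-out lower numbers stand for stronger inhibition and higher numbers for weaker inhibition. Compound 1 `Cc1c(C)c2c(c(C)c1O)CCC(C)(C(=O)N1CCN(c3ncccn3)CC1)O2` gives 23000 nM in this assay. Compound 2 `Cc1c(C)c2c(c(C)c1O)CCC(C)(C(=O)N1CCN(c3ccc(Cl)cc3)CC1)O2` carries a different group on the ring nitrogen, and in this assay compound 2 gives 800 nM. Within the data shown here, the single change between them is 4-chlorophenyl in place of pyrimidin-2-yl on an amine nitrogen in a ring, and it produced a 29-fold lower number from compound 1 to compound 2 (1.46 log units; beyond the scatter).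

Compound 3 `Cc1c(C)c2c(c(C)c1O)CCC(C)(CN1CCN(c3ncccn3)CC1)O2` keeps the pyrimidin-2-yl group of compound 1 but differs from it in the core; the difference between the two cores is not broken down here. In this assay compound 3 gives 1000 nM, a number close to that of compound 2 and far from that of compound 1.

Compound 4 `Cc1c(C)c2c(c(C)c1O)CCC(C)(CN1CCN(c3ccc(Cl)cc3)CC1)O2` has not yet been measured in this assay. Among the measured compounds shown here, it differs from compound 3 by 4-chlorophenyl in place of pyrimidin-2-yl on an amine nitrogen in a ring, the same change in the same place as the one that turned compound 1 into compound 2. The earlier step was large, so the same change on compound 3 is expected to lower the number as well, though probably by less, giving an estimated step of a 17-fold lower number from compound 3 to compound 4 (1.22 log units; beyond the scatter) beside the earlier one, because compound 3 already starts from 1000 nM whereas compound 1 began the earlier step from the much higher 23000 nM. Compound 4 is therefore expected to give about 60 nM in this assay, most likely between 15 nM and 250 nM.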

Compound 4, half-maximal inhibitory concentration: 900 nM
The estimate for compound 4 lay 15-fold (1.18 log units) below the measured number, and the stated range ends below it.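

When the swap of 4-chlorophenyl for pyrimidin-2-yl is made on the second core, this assay shows a 1.1-fold lower number from compound 3 to compound 4 (0.05 log units; within the scatter), so on this core the swap makes no change that can be told from the scatter. The swap therefore does not carry over from one core to the other at the same size: the same change on two cores in this assay, a 29-fold lower number (1.46 log units; beyond the scatter) from compound 1 to compound 2 and a 1.1-fold lower number (0.05 log units; within the scatter) from compound 3 to compound 4, 26-fold (1.41 log units) apart, beyond the scatter of two such steps. Among these compounds, the large step seen on the first core cannot be treated as a fixed gain that comes with the group, but with only one pair on each core, these numbers do not show why the two cores behave differently or what the swap would do on a third core.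

The compounds shown leave open whether other groups on the same ring nitrogen, such as plain phenyl or pyridin-2-yl, would follow the first core's large step or the second core's lack of one. Also open, from the compounds shown here alone, is whether a longer chain, in place of the link that joins the six-membered ring with 2 nitrogen to the rest of the molecule, would alter the size of the swap.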